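This account rests on a few compounds, and the source may have more. Where it says the series, first, only, none or still open, it means among the compounds named here.

Measured in a functional assay on HCT-15 cells (Homo sapiens) for antiproliferative activity, read by sulforhodamine B assay; on this read-out higher numbers stand for weaker inhibition of growth and lower numbers for stronger inhibition of growth:
- Compound 1 `CC(C)CCCOc1cccc(O)c1C(=O)/C=C/c1ccc(O)cc1`: 11600 nM
- Compound 2 `CCCCOc1cccc(O)c1C(=O)/C=C/c1ccc(O)cc1`: > 30000 nM

Compound 2 has no number in this assay, only a limit of the assay, > 30000 nM. Among the measured compounds shown here, the series so far holds (the limit of > 30000 nM in this assay, at which 1 of the 2 values shown sits).

Compound 3 `O=C(/C=C/c1ccc(O)cc1)c1c(O)cccc1OCc1ccccc1` is the next case. It has phenyl in place of propyl on a saturated chain carbon bound to an oxygen on an aromatic ring, so butoxy becomes benzyloxy: phenyl in place of propyl on a saturated chain carbon bound to an oxygen on an aromatic ring.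

For the measured compounds named here, only one measured step bears on this change, and only loosely: an at least 2.5-fold higher number from compound 1 to compound 2 (0.41 log units; beyond the scatter). That step replaced isopropyl with methyl three bonds along the chain from the oxygen, so carbon left the chain and the number rose. Going by the values given here, in the change at hand, carbon is added to the same chain, but an aromatic ring also enters, and no measured compound carries one there.

A modest move towards stronger inhibition of growth is therefore expected, on the strength of an at least 2.5-fold higher number from compound 1 to compound 2 (0.41 log units; beyond the scatter). The expected step is an at least 2.0-fold lower number from compound 2 to compound 3 (0.30 log units; that floor lies within the scatter). Another limit in this assay remains a real possibility. For compound 3 the estimated value is 15000 nM, with an expected range from 6000 nM to 30000 nM.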

Compound 3, concentration for 50% growth inhibition: > 30000 nM
Compound 3 was reported as a limit (the forecaster's own chance of this, stated with the estimate: 35%); at least 2.0-fold (0.30 log units) between middle value and limit.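

In this assay compound 3 gives > 30000 nM, which is a limit of the assay and not a number. The change from butoxy to benzyloxy cannot be read, as both of its ends are limits. Phenyl in place of isopentyl on a saturated chain carbon bound to an oxygen on an aromatic ring gives an at least 2.5-fold higher number from compound 1 to compound 3 (0.41 log units; beyond the scatter), so the first aromatic ring at this place does not keep the growth inhibition seen with the isopentyl chain, and among the groups shown only that chain yields a number: the limit of > 30000 nM in this assay, at which 2 of the 3 values shown sit.

Going by these compounds, the order of butoxy and benzyloxy stays open, as does whether any substituted phenyl at this place would give a number in this assay. Also open, on these data alone, is how a chain longer than isopentyl, or a chain carrying an amine or a carboxylic acid, would read.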